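The source may report more compounds than this note shows. Statements on the series, on what has been measured and on what is new or still open speak of the compounds shown alone.

Working notes on the series.

Compound 1, `Cc1ccc(Nc2nc(Cl)nc3c2ncn3Cc2ccc(C(=O)Nc3ccccc3N)cc2)cc1`, gives 67.3% in a functional assay on NCI-H460 cells (Homo sapiens) for antiproliferative activity, read by CCK-8 assay, with a stated time of 72 h, tested at 2 uM; a higher number here means a stronger effect of the compound at the concentration tested, a lower number a weaker effect. Compound 2, `Cc1ccc(Nc2nc(Cl)nc3c2ncn3Cc2ccc(/C=C/C(=O)Nc3ccccc3N)cc2)cc1`, differs from it in one place, (2-((2-aminophenyl)carbamoyl)ethenyl in place of (2-aminophenyl)carbamoyl on an aromatic carbon), and in this assay compound 2 gives 31.3%. That change made a number 36 percentage points lower from compound 1 to compound 2 (beyond the scatter), a large step beyond the scatter.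

Compound 3, `CC(C)n1cnc2c(Nc3cccc(Cl)c3)nc(NCOCc3ccc(C(=O)Nc4ccccc4N)cc3)nc21`, is built on a different core; the difference between the core of compound 1 and the core of compound 3 is not broken down here. In this assay, among the compounds with values here, compound 3 gives 28.9%, the lowest of the three numbers so far, within the scatter of compound 2 and well below compound 1.

Compound 4, `CC(C)n1cnc2c(Nc3cccc(Cl)c3)nc(NCOCc3ccc(/C=C/C(=O)Nc4ccccc4N)cc3)nc21`, has not been measured. It carries the same change relative to compound 3 that compound 2 carries relative to compound 1: 2-((2-aminophenyl)carbamoyl)ethenyl in place of (2-aminophenyl)carbamoyl on an aromatic carbon. The place is the same in both pairs, so this is the same change, made a second time on the other core.

Within the data shown here, the only precedent for this change is the drop of a number 36 percentage points lower from compound 1 to compound 2 (beyond the scatter). Compound 3 starts from a much lower number, so a drop of the same size cannot be fully realised; a smaller downward step is expected, giving a number 16.9 percentage points lower from compound 3 to compound 4 (beyond the scatter). Compound 4 is therefore expected to give about 12% in this assay, with a likely range from 0% to 30%.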

Compound 4, a percentage reported as inhibition, at one concentration (the size of the read-out at that concentration, not a potency): 53%
For compound 4 the middle estimate is 41 percentage points below the measured one, and the stated range ends below it.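

On the core of compound 3, putting 2-((2-aminophenyl)carbamoyl)ethenyl in place of (2-aminophenyl)carbamoyl gives a number 24.1 percentage points higher from compound 3 to compound 4 (beyond the scatter) in this assay, so the effect of the change does not carry over from the core of compound 1 to this one. The same change, on an aromatic carbon para to a large group in both pairs, therefore moves the read-out in opposite directions on the two cores, and the two steps differ by more than their combined scatter: the same change on two cores in this assay, a number 36 percentage points lower (beyond the scatter) from compound 1 to compound 2 and a number 24.1 percentage points higher (beyond the scatter) from compound 3 to compound 4, 60.1 percentage points apart, beyond the scatter of two such steps. This shows that, in these two pairs, the outcome of the change depends on the core it is made on, but it does not show which part of the core is responsible, since the two cores differ in more than one place, nor does it give a rule for any further core, as it rests on two pairs at a single concentration in one cell line.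

The compounds shown leave open which of the differences between the two cores decides the direction of the step. They also leave open how a saturated ethylene link, or a hydroxamic acid in place of the 2-aminophenyl amide, would behave on each core.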